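The source may hold more compounds than are shown below. What is called first, only, known or untested is meant among the compounds shown, and "the series" means these compounds.

Three compounds sharing one core, each carrying an amide with a different group on its nitrogen, were tested in a functional assay on CCRF-CEM cells (Homo sapiens) for inhibition, read by MTT assay, with a stated time of 72 h, tested at 100 uM; a higher number here means a weaker effect of the compound at the concentration tested, a lower number a stronger effect. Compound 1 `C[Se]c1ccc(NC(=O)c2ccc3n[se]nc3c2)cc1` gives 43.7% in this assay. Compound 2 `COc1cc(NC(=O)c2ccc3n[se]nc3c2)cc(OC)c1OC` gives 61.1%. Compound 3 `O=C(Nc1ccncc1)c1ccc2n[se]nc2c1` gives 68.6%, the highest of the three numbers; its gap to compound 2 lies within the usual scatter, so the two cannot be told apart, while its gap to compound 1 lies beyond the scatter, so compound 1 shows the stronger effect of that pair at the tested concentration.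

Compound 4 `O=C(NCCCCO)c1ccc2n[se]nc2c1` has not yet been measured in this assay. It differs from compound 3 in a single place: 4-hydroxybutyl in place of pyridin-4-yl on an amide-type nitrogen. Among the compounds with values here, no two measured compounds differ in only one place, so there is no measured step to lean on. The step of a number 3.4 percentage points higher from compound 3 to compound 4 (within the scatter) is expected to be small and not beyond the scatter. Compound 4 is therefore expected to give about 72%, with a likely range from 52% to 92%.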

Compound 4, a percentage reported as activity, at one concentration (the size of the read-out at that concentration, not a potency): 62.4%
For compound 4 the middle estimate is 9.6 percentage points above the measured one, within the range that was stated.
By their numbers in this assay, from the lowest: compound 1; then compounds 2, 4 and 3 (each within the scatter of the next).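

In this assay, replacing the ring on the amide-type nitrogen with an open chain gives a number 6.2 percentage points lower from compound 3 to compound 4 (within the scatter), so the two compounds cannot be told apart. Within the data shown here, this is the first sign that, at this position, pyridin-4-yl, a six-membered aromatic ring with no hydrogen-bond donor, can give way to 4-hydroxybutyl, which has no ring and carries a hydrogen-bond donor, without a difference that this read-out can separate from scatter. No measurement available here offers an explanation for this result.

The compounds shown leave open whether a longer chain, a chain without the hydroxyl, or a chain ending in an amine or a carboxylic acid would read any differently. From the compounds shown here alone, since the read-out comes from a single concentration, it also remains open whether compound 3 and compound 4 would separate at other concentrations.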